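The source may hold more compounds than are shown below. What is called first, only, known or untested is meant among the compounds shown, and "the series" means these compounds.

Measured so far in a functional assay on NIH3T3 cells for agonist activity at Urotensin-2 receptor (Homo sapiens), with a stated time of 5 days; on this read-out higher numbers stand for an effect only at larger amounts of compound and lower numbers for an effect already at smaller amounts:
compound 1 `Cc1ccc(C(CCN(C)C)NC(=O)CCc2ccccc2)cc1` gives 4570 nM
compound 2 `Cc1ccc(C(CCN(C)C)NC(=O)CCc2ccc(C(F)(F)F)cc2)cc1` gives 2290 nM
compound 3 `COc1ccc(CCC(=O)NC(CCN(C)C)c2ccc(Cl)cc2)cc1` gives 2950 nM

Compound 3 stands between the other two on the numbers shown, with compound 2 and compound 1 both within the scatter of it, so no order among the three is secured. Compound 4 `COc1ccc(CCC(=O)NC(CCN(C)C)c2ccc(C)cc2)cc1` is not yet measured. It differs from compound 3 by methyl in place of chloro on an aromatic carbon. Going by the values given here, the only measured step, a 2.0-fold lower number from compound 1 to compound 2 (0.30 log units; within the scatter), concerns a substituent on the other aromatic ring and bears on the present change only in showing that a single substituent swap on a ring left the number within the scatter. Among the compounds with values here, no measured pair sets chloro against methyl. For compound 4 the expected step in this assay is a 1.2-fold higher number from compound 3 to compound 4 (0.07 log units; within the scatter), not beyond the scatter. The estimate for compound 4 is 3500 nM, with a range from 1500 nM to 8000 nM.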

Compound 4, half-maximal effective concentration: 5370 nM
The estimate for compound 4 lay 1.5-fold (0.19 log units) below the measured number; the measured number falls inside the stated range.
By their numbers in this assay, from the lowest: compounds 2, 3, 1 and 4 (each within the scatter of the next, the first and the last beyond it).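

In this assay, methyl in place of chloro, para to a large group, gives a 1.8-fold higher number from compound 3 to compound 4 (0.26 log units; within the scatter), so the only swap shown on this ring stays within the scatter. Going by these compounds alone, on the other aromatic ring, methoxy in place of trifluoromethyl gives a 2.3-fold higher number from compound 2 to compound 4 (0.37 log units; beyond the scatter), the only step here beyond the scatter, and it is modest, while methoxy in place of hydrogen gives a 1.2-fold higher number from compound 1 to compound 4 (0.07 log units; within the scatter). No measurement at hand accounts for these steps.

Open, on these data alone, is whether an amine or a carboxylic acid in place of the chloro would move the number beyond the scatter. Also open, as far as these compounds go, is how a longer chain on the amide side would read.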